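Moving the methyl group on compound 1

A few compounds are considered here, and "the series" means these few. Any claim that something is new, unique, unknown or untested is made for them only; others in the source may bear on it.

In a functional assay on SK-BR-3 cells (Homo sapiens) for antiproliferative activity, read by MTT assay, with a stated time of 72 h (on this read-out higher numbers stand for weaker inhibition and lower numbers for stronger inhibition), compound 1 `CCN1CCN(c2cc(C)c3cc(NC(=O)c4ccc(C)cc4)ccc3n2)CC1` gives 11400 nM as its value. This lies within the scatter of compound 2 `Cc1cc(NCCN(C)C)nc2ccc(NC(=O)c3ccc(Cl)c(Cl)c3)cc12` at 6670 nM. On the same read-out compound 3 `CCNc1cc(C)c2cc(NC(=O)c3ccc(Cl)c(Cl)c3)ccc2n1` gives 28200 nM, and the number for compound 1 is lower than this one, beyond the scatter.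

Compound 4 `CCN1CCN(c2cc(C)c3cc(NC(=O)c4ccccc4C)ccc3n2)CC1` has the same atoms as compound 1, joined differently, with 2-methylphenyl in place of 4-methylphenyl on a carbonyl carbon. Going by the values given here, the only measured step is a 4.2-fold higher number from compound 2 to compound 3 (0.63 log units; beyond the scatter) with hydrogen in place of dimethylamino on a saturated chain carbon. Among the compounds with values here, that modest step concerns a different part of the structure, and no measured pair tests this exchange of methylphenyl groups, so it gives no size to carry over.

The expectation therefore stays anchored on compound 1 at 11400 nM in this assay with no shift beyond the scatter in either direction. The estimated change is a 1.1-fold higher number from compound 1 to compound 4 (0.02 log units; within the scatter) for now. The value expected for compound 4 is 12000 nM as the estimate, within an estimated range of 5000 nM to 30000 nM for this measurement.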

Compound 4, half-maximal inhibitory concentration: 29200 nM
Estimate against measurement, compound 4: 2.4-fold (0.39 log units) below; the measured number falls inside the stated range.
By their numbers in this assay, from the lowest: compounds 2 and 1 (each within the scatter of the next); then compounds 3 and 4 (each within the scatter of the next).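

In this assay, 2-methylphenyl in place of 4-methylphenyl on a carbonyl carbon gives a 2.6-fold higher number from compound 1 to compound 4 (0.41 log units; beyond the scatter), so this first measured change at the carbonyl carbon weakens inhibition modestly. The earlier step concerned a dimethylamino group on a saturated chain carbon; this one shows that the read-out also responds at the carbonyl carbon, even though the leaving and entering groups have the same heavy-atom count and the two compounds have the same atoms. No measurement shown here accounts for the shift.

The compounds shown leave open how phenyl carrying no methyl, or a chlorine or methoxy group in place of the methyl, would compare on the same carbonyl carbon. They also leave open whether this exchange of methylphenyl groups gives a step of similar size when the ethylpiperazine is replaced by a dimethylaminoethylamine chain.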